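Cyclopropyl in place of dimethylamino: clearance expectation

The source may report more compounds than this note shows. Statements on the series, on what has been measured and on what is new or still open speak of the compounds shown alone.

Within the data shown here, in an ADME assay on microsomes from liver (Rattus norvegicus) for metabolic stability (on this read-out higher numbers stand for fast clearance and lower numbers for slow clearance), compound 2 `CNc1nc(NC2(C#N)CCCCC2)nc(N(C)C)n1` gives 276 mL/min/kg, the highest of the two numbers so far; compound 1 `CCCC(C#N)(CCC)Nc1nc(NC)nc(-n2cncn2)n1` gives 32 mL/min/kg, and the gap between them lies beyond the scatter. Compound 3 `CNc1nc(NC2(C#N)CCCCC2)nc(C2CC2)n1` has not yet been measured. It differs from compound 2 in one place: cyclopropyl in place of dimethylamino on an aromatic carbon. Among the measured compounds shown here, no step between measured compounds covers this change, so the expectation rests on compound 2 alone. A modest drop is expected, a 2.0-fold lower number from compound 2 to compound 3 (0.29 log units; within the scatter), not clearly beyond the scatter. Compound 3 is therefore estimated at 140 mL/min/kg in this assay, within a range from 55 mL/min/kg to 320 mL/min/kg.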

Compound 3, clearance: 276 mL/min/kg
Estimate against measurement, compound 3: 2.0-fold (0.29 log units) below, and the stated range covers the measured number.
By their numbers in this assay, from the lowest: compound 1; then compounds 2 and 3 (each within the scatter of the next).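

In this assay, cyclopropyl in place of dimethylamino on this aromatic carbon, opposite the ring nitrogen, gives no change at the digits printed from compound 2 to compound 3 (within the scatter) with the rest of the structure held fixed. At this position, then, an all-carbon three-membered ring and a dimethylamino group with its nitrogen acceptor cannot be told apart on clearance. No measurement at hand accounts for this flat step.

As far as these compounds go, whether a morpholine, a carboxylic acid or a longer alkyl chain at this position would also leave clearance unmoved remains open. Also open, from the compounds shown here alone, is whether the same swap would read alike with a different amino substituent on the shared core.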